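The source may report more compounds than this note shows. Statements on the series, on what has been measured and on what is new or still open speak of the compounds shown alone.

Compound 1 `C=C(C)CCOC(=O)C1=C(C)NC(C)=C(C(=O)OC)C1c1cccc([N+](=O)[O-])c1` gives 23 nM in a functional assay on HEK293 cells for antagonist activity at Voltage-dependent L-type calcium channel subunit alpha-1C (Oryctolagus cuniculus), read by FLIPR; on this read-out higher numbers stand for weaker inhibition and lower numbers for stronger inhibition.
Compound 2 `COC(=O)C1=C(C)NC(C)=C(C(=O)OCCCl)C1c1cccc([N+](=O)[O-])c1` gives 26 nM in this assay.

On these two numbers compound 2 sits beside compound 1: the step of a 1.1-fold higher number from compound 1 to compound 2 (0.05 log units; within the scatter) is within the scatter, so neither compound can be told apart from the other in this assay.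

Compound 3 `COC(=O)C1=C(C)NC(C)=C(C(=O)OCC(F)(F)F)C1c1cccc([N+](=O)[O-])c1` differs from compound 2 by trifluoromethyl in place of chloromethyl on a saturated chain carbon bound to an oxygen next to a carbonyl group. For the measured compounds named here, the only measured step that bears on this is the one on the same ester chain, a 1.1-fold higher number from compound 1 to compound 2 (0.05 log units; within the scatter), where a different group on that chain left the number essentially unchanged. The present change is of a similar kind and stays on the same chain, so no step beyond the scatter is expected in this assay; the expected step is a 1.2-fold higher number from compound 2 to compound 3 (0.06 log units; within the scatter). Compound 3 is therefore estimated at 30 nM, with a likely range from 12 nM to 75 nM.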

Compound 3, half-maximal inhibitory concentration: 16 nM
Compound 3: middle estimate off by 1.9-fold (0.27 log units), on the high side; the measured number falls inside the stated range.
By their numbers in this assay, from the lowest: compounds 3, 1 and 2 (each within the scatter of the next).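

In this assay trifluoromethyl in place of chloromethyl, on a saturated chain carbon bound to an oxygen next to a carbonyl group, gives a 1.6-fold lower number from compound 2 to compound 3 (0.21 log units; within the scatter) and trifluoromethyl in place of 2-methylprop-2-en-1-yl gives a 1.4-fold lower number from compound 1 to compound 3 (0.16 log units; within the scatter) as the second step at this place. Both steps lie within the scatter, so the three compounds cannot be told apart, and this ester chain has now carried a fluorine-bearing, a chlorine-bearing and an alkene-bearing end with no step beyond the scatter. No supporting measurement is available to explain this result.

As far as these compounds go, whether an amine, a carboxylic acid or a much longer chain at this place would give a similar number remains open. The rest of the shared core is identical in all three compounds, so the effect of changes there is also unknown.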